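The compounds below may be only part of what the source reports. "The series", "measured", "known", "first", "only" and "open" are said of these compounds alone.

Compound 1 `O=C1N=C(Nc2ccc(O)cc2)S/C1=C\c1ccc(Cl)cc1` carries a 4-hydroxyphenyl on its amine nitrogen and a chloro-substituted aromatic ring at the other end of the shared core. In a functional assay on OVCAR-3 cells (Homo sapiens) for cytotoxicity (a lower number here means a stronger inhibitor of growth, a higher number a weaker inhibitor of growth), compound 1 gives 162 nM, the lowest of the three numbers measured. Compound 2 `O=C1N=C(Nc2ccc(O)cc2)S/C1=C\c1ccc(F)cc1` differs from it only at that far ring, and in this assay compound 2 gives 324 nM; the step of a 2.0-fold higher number from compound 1 to compound 2 (0.30 log units; within the scatter) stays within the scatter. Compound 3 `O=C1N=C(Nc2cccc(O)c2)S/C1=C\C(Cl)=C/c1ccc([N+](=O)[O-])cc1` changes both ends of the core at once and in this assay compound 3 gives 372 nM, a gap from compound 1 that lies beyond the scatter but cannot be pinned on either end alone.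

Compound 4 `O=C1N=C(Nc2cccc(O)c2)S/C1=C\c1ccc(Cl)cc1` is built from compound 1 by the change (3-hydroxyphenyl in place of 4-hydroxyphenyl on an amine nitrogen). Among the compounds with values here, no measured step isolates this change; the only measured step, from compound 1 to compound 2, touches a different ring and was small. The expectation is therefore a step of a 1.2-fold higher number from compound 1 to compound 4 (0.09 log units; within the scatter) of no clear size in either direction beyond the scatter. Compound 4 is estimated at 200 nM, with a range from 80 nM to 500 nM.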

Compound 4, concentration for 50% growth inhibition: 490 nM
Beside the measured number, compound 4's estimate is 2.5-fold (0.39 log units) below it; low and high end bracket the measured number.
By their numbers in this assay, from the lowest: compounds 1, 2, 3 and 4 (each within the scatter of the next, the first and the last beyond it).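

Replacing 4-hydroxyphenyl with 3-hydroxyphenyl on the amine nitrogen gives, in this assay, a 3.0-fold higher number from compound 1 to compound 4 (0.48 log units; beyond the scatter). Within the data shown here, this is the first measured step at this end of the shared core, and it shows that this end responds to a change even when the atoms stay the same: the two groups have identical atoms and identical counts of hydrogen-bond donors and acceptors, yet the step lies beyond the scatter, whereas a 2.0-fold higher number from compound 1 to compound 2 (0.30 log units; within the scatter) stays within it. No measured evidence here accounts for this shift.

Still open, as far as these compounds go, is how an amine or a carboxylic acid in place of the hydroxyl on this ring would compare. Also open, from the compounds shown here alone, is whether the same swap would give a step of similar size in compound 2, with fluoro on the far ring.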